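Swapping a Cyclobutyl for a Pyridin-2-yl: Expected Cytotoxicity

The source may report more compounds than this note shows. Statements on the series, on what has been measured and on what is new or still open speak of the compounds shown alone.

Of the compounds shown here, three built on a shared core have been tested in an ADME assay on Huh-7 cells (Homo sapiens) for cytotoxicity, with a stated time of 72 h; on this read-out higher numbers stand for lower toxicity in this test and lower numbers for higher toxicity in this test. Compound 1 `CS(=O)(=O)Nc1ccc2c(c1)S(=O)(=O)N=C(C1=C(O)C3CCCCCCC3N(Cc3ccc(F)cc3)C1=O)N2` gives > 33000 nM in this assay, which is a limit of the assay. Compound 2 `CS(=O)(=O)Nc1ccc2c(c1)S(=O)(=O)N=C(C1=C(O)C3CCCC3N(CC3CCC3)C1=O)N2` gives > 33000 nM in this assay, again a limit. Compound 3 `CS(=O)(=O)Nc1ccc2c(c1)S(=O)(=O)N=C(c1c(O)c3cccn3n(Cc3ccc(F)cc3)c1=O)N2` gives > 1000 nM in this assay, also a limit. Compound 2 thus stands at the limit of > 33000 nM in this assay, at which 2 of the 3 values shown sit. The remaining value sits at the limit of > 1000 nM in this assay, at which 1 of the 3 values shown sits. For the measured compounds named here, no pair of measured compounds differs in a single place, so no measured step size exists for this core.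

Compound 4 `CS(=O)(=O)Nc1ccc2c(c1)S(=O)(=O)N=C(C1=C(O)C3CCCC3N(Cc3ccccn3)C1=O)N2` has not yet been measured. It differs from compound 2 in one place: pyridin-2-yl in place of cyclobutyl on a saturated chain carbon bound to an amide-type nitrogen in a ring. Since every value on this core is a limit and no change has yet produced a measured step, the expected step that the limit leaves unreadable from compound 2 to compound 4 is none beyond the scatter. Compound 4 is therefore expected to give about 50000 nM in this assay, with a range from 20000 nM to 150000 nM, and most likely to be reported again only as a limit.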

Compound 4, half-maximal cytotoxic concentration: > 33000 nM
Compound 4: a limit, no number; the forecaster's own chance of this, stated with the estimate: 85%; the middle value does not contradict the limit.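

Compound 2 and compound 4 each give only a limit and not a number, so no step between them can be read: the limit of > 33000 nM in this assay, at which 3 of the 4 values shown sit.

The compounds shown leave open whether pyridin-2-yl in place of cyclobutyl changes cytotoxicity at all, and at what concentration any of these compounds becomes toxic.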